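Swapping phenoxy for bromo on compound 3

The source may report more compounds than this note shows. Statements on the series, on what has been measured and on what is new or still open speak of the compounds shown alone.

Measured so far in an ADME assay for permeability, using PAMPA, at pH 7.4; on this read-out higher numbers stand for higher permeability and lower numbers for lower permeability:
- compound 1 `CCOC(=O)c1c(-c2cccc(OCC)c2)[nH]c2cc(OC)ccc2c1=O`: 260 10^-6 cm/s
- compound 2 `CCOC(=O)c1c(-c2cccc(Oc3ccccc3)c2)[nH]c2cc(OC)ccc2c1=O`: 750 10^-6 cm/s
- compound 3 `CCOC(=O)c1c(-c2cccc(Oc3ccccc3)c2)[nH]c2cc(OC)c(F)cc2c1=O`: 560 10^-6 cm/s

Compound 3 lies within the scatter of compound 2, and its number is clearly higher than that of compound 1. Compound 4 `CCOC(=O)c1c(-c2cccc(Br)c2)[nH]c2cc(OC)c(F)cc2c1=O` carries bromo in place of phenoxy on an aromatic carbon. Among the compounds with values here, no measured compound carries bromo, so the guidance is indirect. The closest step is a 2.9-fold higher number from compound 1 to compound 2 (0.46 log units; beyond the scatter), where phenyl replaced ethyl on an oxygen. Fluoro matters little here, given a 1.3-fold lower number from compound 2 to compound 3 (0.13 log units; within the scatter). Losing the phenoxy should therefore give back a similar amount. A modest fall is expected, a 1.9-fold lower number from compound 3 to compound 4 (0.27 log units; within the scatter). Compound 4 is estimated at 300 10^-6 cm/s, with an expected range of 150 10^-6 cm/s to 600 10^-6 cm/s.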

Compound 4, apparent permeability in the ADME assay: 670 10^-6 cm/s
Estimate against measurement, compound 4: 2.2-fold (0.35 log units) below; measured number outside the range, above it.
By their numbers in the ADME assay, from the lowest: compound 1; then compounds 3, 4 and 2 (each within the scatter of the next).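

In the ADME assay, bromo in place of phenoxy gives a 1.2-fold higher number from compound 3 to compound 4 (0.08 log units; within the scatter), so at this place phenoxy, with 7 heavy atoms and one six-membered aromatic ring of carbon only, and bromo, with 1 heavy atom, cannot be told apart on this read-out. In a physicochemical assay for solubility, at pH 7.4 (a higher number here means a more soluble compound, a lower number a less soluble compound), compound 3 gives 4300 nM and compound 4 gives 7300 nM; the same change gives a 1.7-fold higher number from compound 3 to compound 4 (0.23 log units; within the scatter), which also lies within the scatter. No measured evidence here gives a reason for this result.

An amine or a carboxylic acid at this place remains an open case. Also open, on these data alone, is whether the bromo result holds on a core without the fluoro.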